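Swapping hydroxy for nitro: expected effect on cell toxicity

The source may hold more compounds than are shown below. What is called first, only, known or untested is meant among the compounds shown, and "the series" means these compounds.

compound 1 `COc1ccc(/C(C)=N/c2nc(C)nc(OC)n2)cc1` — "not determined" (no result reported)
compound 2 `COc1nc(C)nc(/N=C(\C)c2ccc(O)cc2)n1` — > 50 ug/mL

Compound 1 has no result in this assay. For compound 2 the value is only a limit of the assay, > 50 ug/mL, as noted in the limit of > 50 ug/mL in this assay, at which 1 of the 2 values shown sits. Compound 3 `COc1nc(C)nc(/N=C(\C)c2ccc([N+](=O)[O-])cc2)n1` differs from it by nitro in place of hydroxy on an aromatic carbon. Within the data shown here, with no measured step to lean on, the expected change in an ADME assay on Vero cells (Chlorocebus sabaeus) for cytotoxicity, read by MTT assay, with a stated time of 72 h (on this read-out higher numbers stand for weaker inhibition and lower numbers for stronger inhibition), is a step that the limit leaves unreadable from compound 2 to compound 3, none beyond the scatter. Compound 3 is therefore estimated at 60 ug/mL, with a range from 25 ug/mL to 150 ug/mL.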

Compound 3, half-maximal inhibitory concentration: > 50 ug/mL
Compound 3 was reported as a limit; the forecaster's own chance of this, stated with the estimate: 65%; the middle value is on the limit's open side.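

Compound 2 and compound 3 give no readable step, because both values are limits rather than numbers: the limit of > 50 ug/mL in this assay, at which 2 of the 3 values shown sit.

From the compounds shown here alone, whether nitro in place of hydroxy changes cell toxicity at all, and by how much, stays open.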